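This account rests on a few compounds, and the source may have more. Where it says the series, first, only, none or still open, it means among the compounds named here.

Measured compounds:
Compound 1, `COC(=O)C1=C(C)NC(=O)NC1c1cccc([N+](=O)[O-])c1`: in an assay on HEK293 cells for antagonist activity at Voltage-dependent L-type calcium channel subunit alpha-1D (Rattus norvegicus), read by FLIPR (a higher number here means a weaker inhibitor, a lower number a stronger inhibitor), compound 1 gives 18900 nM.
Compound 2, `COC(=O)C1=C(C(C)C)NC(=O)NC1c1cccc([N+](=O)[O-])c1`: compound 2 gives only a limit of this assay, > 100000 nM.

Among the measured compounds shown here, the single measured step is an at least 5.2-fold higher number from compound 1 to compound 2 (0.72 log units; beyond the scatter), and its size is bounded rather than exact because compound 2 sits at the limit of > 100000 nM in this assay, at which 1 of the 2 values shown sits. Compound 2 therefore stands at the weaker end of the two values shown, known only as a limit and not as a number.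

Compound 3, `CCOC(=O)N1C(=O)NC(C(C)C)=C(C(=O)OC)C1c1cccc([N+](=O)[O-])c1`, differs from compound 2 by ethoxycarbonyl in place of hydrogen on an amide-type nitrogen in a ring. For the measured compounds named here, no measured step concerns a change on this ring nitrogen; the only step on record, from compound 1 to compound 2, concerns the isopropyl group and already carries the series to the limit. There is thus no measured basis for expecting a move in either direction beyond the scatter, and the starting point itself is unresolved.

Compound 3 is accordingly estimated at 150000 nM, with a range from 40000 nM to 600000 nM. The expected step is a step that the limit leaves unreadable from compound 2 to compound 3, and it is expected that compound 3 will most likely again be reported only as a limit.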

Compound 3, half-maximal inhibitory concentration: 24500 nM
For compound 3 the middle estimate is 6.1-fold (0.79 log units) above the measured one, outside the stated range (below it).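

In this assay, ethoxycarbonyl in place of hydrogen on the amide-type nitrogen in the ring brings a change that can be read, with an at least 4.0-fold lower number from compound 2 to compound 3 (0.61 log units; beyond the scatter). For compound 2 the reading is only a limit, > 100000 nM. The isopropyl group on the ring therefore does not by itself keep a compound of this series beyond a measurable reading, as compound 3, which carries that group together with ethoxycarbonyl on the ring nitrogen, gives 24500 nM, so this nitrogen emerges as a position where a substituent can be tolerated and can make a clear difference to the number.

The compounds shown leave open whether the step depends on ethoxycarbonyl itself or whether an acetyl group, a methyl group or a longer alkoxycarbonyl chain on this nitrogen would do the same. They also leave open how large the step truly is, and whether ethoxycarbonyl on this nitrogen would shift the number in the same direction for compound 1, which has methyl in place of isopropyl.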